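This account rests on a few compounds, and the source may have more. Where it says the series, first, only, none or still open, it means among the compounds named here.

Compound 3 `COc1ccc(-c2cn3cc(C4=CCN(C(=O)c5cccc(C(F)(F)F)c5)CC4)ccc3n2)cc1OC` gives 3690 nM in a functional assay on A549 cells (Homo sapiens) for antiproliferative activity, read by MTT assay, with a stated time of 48 h (a lower number here means a stronger inhibitor, a higher number a weaker inhibitor), the smallest of the three numbers, though within the scatter of compound 1. Compound 1 `COc1ccc(-c2cn3cc(C4=CCN(C(=O)C5CCCCC5)CC4)ccc3n2)cc1OC` gives 7310 nM and compound 2 `COc1ccc(-c2cn3cc(C4=CCN(C(=O)c5ccccc5)CC4)ccc3n2)cc1OC` gives 7700 nM. Compound 4 `COc1ccc(-c2cn3cc(C4=CCN(C(=O)c5cccs5)CC4)ccc3n2)cc1OC` differs from compound 3 by thiophen-2-yl in place of 3-(trifluoromethyl)phenyl on a carbonyl carbon. For the measured compounds named here, the steps that bear on this exchange of one ring for another on the carbonyl carbon are a 1.1-fold higher number from compound 1 to compound 2 (0.02 log units; within the scatter) and a 2.0-fold lower number from compound 1 to compound 3 (0.30 log units; within the scatter), both small; the only change beyond the scatter, a 2.1-fold lower number from compound 2 to compound 3 (0.32 log units; beyond the scatter), is modest. Compound 2, carrying a ring without trifluoromethyl, gives 7700 nM, so a similar or somewhat higher number is expected for compound 4. Compound 4 is therefore expected to give 6000 nM, between 2500 nM and 14000 nM. The expected step is a 1.6-fold higher number from compound 3 to compound 4 (0.21 log units; within the scatter), close to the scatter.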

Compound 4, half-maximal inhibitory concentration: 5200 nM
Compound 4: the middle estimate sits 1.2-fold (0.06 log units) above what was measured; measured number inside the range.
By their numbers in this assay, from the lowest: compounds 3, 4, 1 and 2 (each within the scatter of the next, the first and the last beyond it).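

In this assay, a five-membered aromatic ring with 1 hetero atom on the carbonyl carbon stays within the scatter of all three six-membered rings (a 1.4-fold higher number from compound 3 to compound 4 (0.15 log units; within the scatter); a 1.5-fold lower number from compound 2 to compound 4 (0.17 log units; within the scatter); a 1.4-fold lower number from compound 1 to compound 4 (0.15 log units; within the scatter)). Trifluoromethyl is therefore not needed to stay within the scatter of compound 3, although compound 2 and compound 3 remain the one pair beyond it. No measurement shown explains this narrow spread.

Open, on these data alone, is whether an amine or a carboxylic acid on this ring, or a longer chain in its place, would move the number beyond the scatter of compound 3.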